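Replacing a methoxyphenyl with a methylphenyl on the quinoline

A few compounds are considered here, and "the series" means these few. Any claim that something is new, unique, unknown or untested is made for them only; others in the source may bear on it.

Compounds measured so far:
compound 1, `COc1cc2c(Oc3ccc(NC(=O)c4cc(-c5ccc(C)cc5)nc5ccccc45)cc3F)ccnc2cc1OCCCN1CCC(C)CC1`, 1260 nM
compound 2, `COc1cc2c(Oc3ccc(NC(=O)c4cc(-c5ccc(Cl)c(Cl)c5)nc5ccccc45)cc3F)ccnc2cc1OCCCN1CCCC1`, 340 nM
compound 3, `COc1cccc(-c2cc(C(=O)Nc3ccc(Oc4ccnc5cc(OCCCN6CCCC6)c(OC)cc45)c(F)c3)c3ccccc3n2)c1`, 790 nM

In a functional assay on SMMC-7721 cells (Homo sapiens) for cytotoxicity, read by MTT assay, with a stated time of 72 h (on this read-out lower numbers stand for stronger inhibition and higher numbers for weaker inhibition), compound 3 gives 790 nM. For the measured compounds named here, its number lies within the scatter of that of compound 1, which gives 1260 nM, so no order can be read between these two; the only step beyond the scatter is a 2.3-fold higher number from compound 2 to compound 3 (0.37 log units; beyond the scatter).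

The change now followed, from compound 3 to compound 4 `COc1cc2c(Oc3ccc(NC(=O)c4cc(-c5ccc(C)cc5)nc5ccccc45)cc3F)ccnc2cc1OCCCN1CCCC1`, is 4-methylphenyl in place of 3-methoxyphenyl on an aromatic carbon. Going by the values given here, no measured step touches this change directly: compound 1 carries the same 4-methylphenyl but a different amine on the chain, and compound 2 shows only that a 3,4-dichlorophenyl gives a lower number than the 3-methoxyphenyl of compound 3. Among the compounds with values here, the one measured step with a change on this aromatic carbon was modest, and compound 1 sits within the scatter of compound 3. A step of similar or smaller size, without a clear direction, is therefore expected in this assay, a 1.2-fold higher number from compound 3 to compound 4 (0.08 log units; within the scatter).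

Compound 4 is estimated to give 950 nM, with a range from 400 nM to 2200 nM.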

Compound 4, half-maximal inhibitory concentration: 520 nM
The estimate for compound 4 lay 1.8-fold (0.26 log units) above the measured number, and the stated range covers the measured number.
By their numbers in this assay, from the lowest: compounds 2, 4, 3 and 1 (each within the scatter of the next, the first and the last beyond it).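

In this assay, 4-methylphenyl in place of 3-methoxyphenyl gives a 1.5-fold lower number from compound 3 to compound 4 (0.18 log units; within the scatter), and 4-methylphenyl in place of 3,4-dichlorophenyl gives a 1.5-fold higher number from compound 2 to compound 4 (0.18 log units; within the scatter), so at this aromatic carbon next to the ring nitrogen, compound 4 cannot be ordered against either neighbour. For the compounds shown here, the clearer step now lies at the other end of the molecule: with 4-methylphenyl held constant, pyrrolidin-1-yl in place of 4-methylpiperidin-1-yl gives a 2.4-fold lower number from compound 1 to compound 4 (0.38 log units; beyond the scatter), the first reading of a change in the amine on the chain. No available evidence accounts for either result.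

Going by these compounds, whether the amine step holds with 3,4-dichlorophenyl or 3-methoxyphenyl at the aromatic carbon remains open. So does the outcome with other amines on the chain, such as morpholine or dimethylamine, or with an unsubstituted phenyl at the aromatic carbon.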